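Hydroxamic acid in place of aminophenyl amide on the shared core

A few compounds are considered here, and "the series" means these few. Any claim that something is new, unique, unknown or untested is made for them only; others in the source may bear on it.

Measured compounds:
compound 1 `O=C(NO)c1ccc(CNC(=O)c2n[nH]cc2NC(=O)c2ccccc2Cl)cc1` — 21800 nM
compound 2 `Nc1ccccc1NC(=O)c1ccc(CNC(=O)c2n[nH]cc2NC(=O)c2ccccc2F)cc1` — 6850 nM
compound 3 `Nc1ccccc1NC(=O)c1ccc(CNC(=O)c2n[nH]cc2NC(=O)c2ccccc2)cc1` — 6620 nM

In a functional assay on SMMC-7721 cells (Homo sapiens) for inhibition, read by CCK-8 assay, with a stated time of 72 h (on this read-out higher numbers stand for weaker inhibition and lower numbers for stronger inhibition), compound 2 gives 6850 nM, which places it in the middle of the three numbers. Compound 3 sits closest, and the step of a 1.0-fold lower number from compound 2 to compound 3 (0.01 log units; within the scatter) is within the scatter, so nothing separates the two. Among the compounds with values here, compound 1, the only member that carries a hydroxycarbamoyl end, gives 21800 nM, a higher number than either of the (2-aminophenyl)carbamoyl compounds.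

Compound 4 `O=C(NO)c1ccc(CNC(=O)c2n[nH]cc2NC(=O)c2ccccc2F)cc1` is not yet measured. It differs from compound 2 by hydroxy in place of 2-aminophenyl on an amide-type nitrogen, the swap sitting on an amide-type nitrogen whose other neighbour is the carbonyl carbon. Within the data shown here, no measured step covers this exact swap; the only bearing evidence is the pairing of compound 1 against compounds 2 and 3, where the hydroxycarbamoyl compound gives the higher number, and the finding that the change of fluoro to hydrogen between compound 2 and compound 3 makes no difference. On that basis compound 4 is expected to give a higher number than compound 2, a step of about a 2.9-fold higher number from compound 2 to compound 4 (0.47 log units; beyond the scatter) in this assay. The estimate for compound 4 is 20000 nM, with a range from 9000 nM to 45000 nM.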

Compound 4, half-maximal inhibitory concentration: 16700 nM
Compound 4: the middle estimate sits 1.2-fold (0.08 log units) above what was measured; the range from low to high includes it.
By their numbers in this assay, from the lowest: compounds 3 and 2 (each within the scatter of the next); then compounds 4 and 1 (each within the scatter of the next).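

In this assay, the pair of compound 2 and compound 4 isolates the change of hydroxy in place of 2-aminophenyl on the amide-type nitrogen with the fluoro group held constant, which compound 1 could not do because it also differs in its halogen; the pair gives a 2.4-fold higher number from compound 2 to compound 4 (0.39 log units; beyond the scatter) and so shows a modest effect of this swap alone. The other new pair shows that fluoro in place of chloro on an aromatic carbon gives a 1.3-fold lower number from compound 1 to compound 4 (0.12 log units; within the scatter) in the hydroxycarbamoyl compounds, which matches the lack of separation seen for hydrogen in place of fluoro in the (2-aminophenyl)carbamoyl compounds, a 1.0-fold lower number from compound 2 to compound 3 (0.01 log units; within the scatter). Among these four compounds, only the change at the amide-type nitrogen moves the number beyond the scatter, and no compound shown goes against this.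

No accompanying measurement bears on why this swap shifts the number, so its origin remains unknown. On these data alone, it also remains open how a carboxylic acid or a primary amide would read in place of the hydroxycarbamoyl end, and whether a methyl or methoxy group in place of the halogen would stay within the scatter.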